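From 1-methyl-1H-indol-6-yl to 1-methyl-1H-indazol-6-yl on a shared core

The source may hold more compounds than are shown below. What is called first, only, known or untested is meant among the compounds shown, and "the series" means these compounds.

Of the compounds shown here, three with the same core have been tested so far. In a functional assay on A549 cells (Homo sapiens) for inhibition, read by CCK-8 assay, with a stated time of 48 h (a lower number here means a stronger inhibitor, a higher number a weaker inhibitor), compound 1 (`COc1cc(-c2ccnc3cc(-c4ccc(F)cc4)nn23)cc(OC)c1OC`), which carries 4-fluorophenyl, gives 3800 nM as its result. Compound 2 (`COc1cc(-c2ccnc3cc(-c4cn(C)c5ccccc45)nn23)cc(OC)c1OC`), with 1-methyl-1H-indol-3-yl, gives 1340 nM as its result. Compound 3 (`COc1cc(-c2ccnc3cc(-c4ccc5ccn(C)c5c4)nn23)cc(OC)c1OC`), with 1-methyl-1H-indol-6-yl, gives 829 nM as its result. This places compound 3 clearly apart from compound 1 but not from compound 2, as the data show a 4.6-fold lower number from compound 1 to compound 3 (0.66 log units; beyond the scatter) and only a 1.6-fold lower number from compound 2 to compound 3 (0.21 log units; within the scatter) between these pairs.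

Compound 4 (`COc1cc(-c2ccnc3cc(-c4ccc5cnn(C)c5c4)nn23)cc(OC)c1OC`) has not yet been measured. It differs from compound 3 in one place (1-methyl-1H-indazol-6-yl in place of 1-methyl-1H-indol-6-yl on an aromatic carbon) where 1-methyl-1H-indazol-6-yl stands in place of 1-methyl-1H-indol-6-yl on an aromatic carbon.

For the measured compounds named here, no measured step makes this exact change. The nearest guides are a 2.8-fold lower number from compound 1 to compound 2 (0.45 log units; beyond the scatter) and the two steps above, and the two modest ones replaced 4-fluorophenyl entirely. Exchanging 1-methyl-1H-indol-3-yl for 1-methyl-1H-indol-6-yl stayed within the scatter, and the present swap is similarly limited. The expected result is a 1.1-fold higher number from compound 3 to compound 4 (0.04 log units; within the scatter) in this assay and thus no shift beyond the scatter in either direction. Compound 4 is estimated at 900 nM with an expected range of 350 nM to 2300 nM in this test.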

Compound 4, half-maximal inhibitory concentration: 233 nM
For compound 4 the middle estimate is 3.9-fold (0.59 log units) above the measured one, outside the stated range (below it).
By their numbers in this assay, from the lowest: compound 4; then compounds 3 and 2 (each within the scatter of the next); then compound 1.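

The step of a 3.6-fold lower number from compound 3 to compound 4 (0.55 log units; beyond the scatter) in this assay shows that this position responds to a change inside the fused group itself, even though both groups have the same heavy-atom count and attach at the same place: 1-methyl-1H-indazol-6-yl has one more ring nitrogen and one less carbon than 1-methyl-1H-indol-6-yl. The earlier move from 1-methyl-1H-indol-3-yl to 1-methyl-1H-indol-6-yl stayed within the scatter, whereas the new group stands clearly apart from both indole compounds, with a 5.8-fold lower number from compound 2 to compound 4 (0.76 log units; beyond the scatter), and it widens the span from the original 4-fluorophenyl to a 16-fold lower number from compound 1 to compound 4 (1.21 log units; beyond the scatter), making compound 4 the strongest inhibitor of the four. Nothing available here accounts for why this one ring change has such an effect.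

On these data alone, it remains open whether the lower number depends on the methyl on the ring nitrogen, which could be tested with the unmethylated 1H-indazol-6-yl or with an ethyl group in its place. As far as these compounds go, it is also open whether the attachment point matters for the indazole as well, as 1-methyl-1H-indazol-3-yl would show.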